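Methoxy Added Where Chloro Once Lowered the Number

A few compounds are considered here, and "the series" means these few. Any claim that something is new, unique, unknown or untested is made for them only; others in the source may bear on it.

Compound 3 `Cc1ccc(-c2nnc(N3CCN(C(=O)CN4CCN(c5ccccc5)CC4)CC3)nc2-c2ccc(C)cc2)cc1` stands at a limit in an ADME assay on NIH3T3 cells (Mus musculus) for cytotoxicity, read by MTT assay, with a stated time of 24 h (a higher number here means a weaker inhibitor, a lower number a stronger inhibitor), where compound 3 gives > 914000 nM. Compound 1 `O=C(CN1CCN(c2ccccc2)CC1)N1CCN(c2nnc(-c3ccccc3)c(-c3ccccc3)n2)CC1` also stands at a limit in this assay, where compound 1 gives > 963000 nM. Compound 2 `O=C(CN1CCN(c2cccc(Cl)c2)CC1)N1CCN(c2nnc(-c3ccccc3)c(-c3ccccc3)n2)CC1` gives 178000 nM in this assay. For the measured compounds named here, the only measured step, an at least 5.4-fold lower number from compound 1 to compound 2 (0.73 log units; beyond the scatter), is therefore the one evidence on hand. Compound 4 `COc1cccc(N2CCN(CC(=O)N3CCN(c4nnc(-c5ccc(C)cc5)c(-c5ccc(C)cc5)n4)CC3)CC2)c1` differs from compound 3 by methoxy in place of hydrogen on an aromatic carbon. That chloro step bears on this change, though methoxy is a different group, so a lower number of modest size is expected, with a limit still plausible. Compound 4 is estimated to give 500000 nM, between 150000 nM and 1500000 nM, an expected step of an at least 1.8-fold lower number from compound 3 to compound 4 (0.26 log units; that floor lies within the scatter).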

Compound 4, half-maximal inhibitory concentration: > 866000 nM
Compound 4: a limit, no number; the forecaster's own chance of this, stated with the estimate: 55%; at least 1.7-fold (0.23 log units) between middle value and limit.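

In this assay compound 3 and compound 4 both stand at limits, so the step between them cannot be read. The compounds shown leave open whether methoxy in place of hydrogen on an aromatic carbon changes the number at all.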